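From dimethylamino to chloro in a growth inhibitor series

The source may report more compounds than this note shows. Statements on the series, on what has been measured and on what is new or still open speak of the compounds shown alone.

- Compound 1 `Cc1ccc(CS/C(=C/c2sccc2C)C(=O)c2ccc(Cl)cc2)cc1` gives 10000 nM
- Compound 2 `Cc1ccc(CS/C(=C/c2cc([N+](=O)[O-])ccc2F)C(=O)c2ccc(Cl)cc2)cc1` gives 1000 nM
- Compound 3 `Cc1ccc(CS/C(=C/c2ccc(N(C)C)cc2)C(=O)c2ccc(Cl)cc2)cc1` gives > 100000 nM as a limit

In a functional assay on DU-145 cells (Homo sapiens) for inhibition, read by trypan blue exclusion, with a stated time of 96 h (a higher number here means a weaker inhibitor of growth, a lower number a stronger inhibitor of growth), compound 3 has only a limit and not a number (the limit of > 100000 nM in this assay, at which 1 of the 3 values shown sits). Compound 4 `Cc1ccc(CS/C(=C/c2ccc(Cl)cc2)C(=O)c2ccc(Cl)cc2)cc1` carries chloro in place of dimethylamino on an aromatic carbon, para to a large group (chloro in place of dimethylamino on an aromatic carbon). Among the measured compounds shown here, two measured steps bear on this change: an at least 10-fold higher number from compound 1 to compound 3 (1.00 log units; beyond the scatter) and an at least 100-fold higher number from compound 2 to compound 3 (2.00 log units; beyond the scatter) both bring in 4-(dimethylamino)phenyl, one at least modest and the other large. Neither of them tests chloro, so the size stays uncertain. Compound 4 gives that group up, so the expected step in this assay is an at least 20-fold lower number from compound 3 to compound 4 (1.30 log units; beyond the scatter) toward stronger growth inhibition. Compound 4 is estimated at 5000 nM with 700 nM to 40000 nM as its expected range.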

Compound 4, concentration for 50% growth inhibition: 10000 nM
Beside the measured number, compound 4's estimate is 2.0-fold (0.30 log units) below it; measured number inside the range.
By their numbers in this assay, from the lowest: compound 2; then compounds 1 and 4 (each within the scatter of the next). At a limit, above all of these: compound 3.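

Compound 3 has no number here, only a limit: the limit of > 100000 nM in this assay, at which 1 of the 4 values shown sits. In this assay, replacing dimethylamino with chloro gives an at least 10-fold lower number from compound 3 to compound 4 (1.00 log units; beyond the scatter), so a measurable value returns with dimethylamino gone. Setting 4-chlorophenyl against the other groups gives no change at the digits printed from compound 1 to compound 4 (within the scatter) for 3-methylthiophen-2-yl and a 10-fold higher number from compound 2 to compound 4 (1.00 log units; beyond the scatter) for 2-fluoro-5-nitrophenyl.

On these data alone, whether losing dimethylamino or gaining chloro matters more remains open. A plain hydrogen, a methoxy or an amine at this same carbon could help separate the two.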